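Shifting the Chloro Group: From Compound 1 to Compound 4

The source may hold more compounds than are shown below. What is called first, only, known or untested is meant among the compounds shown, and "the series" means these compounds.

Compound 1 `FC(F)(F)c1ccc(CSc2nc(Nc3ccccc3Cl)c3ccccc3n2)cc1` was tested in a functional assay on HGC-27 cells (Homo sapiens) for cytotoxicity, read by MTT assay, with a stated time of 72 h (a lower number here means a stronger inhibitor, a higher number a weaker inhibitor), and gave only a limit, > 50000 nM. Compound 2 `CCOc1ccccc1Nc1nc(SCc2ccc(C(F)(F)F)cc2)nc2ccccc12` also gave only a limit in this assay, > 50000 nM. Compound 3 `FC(F)(F)c1ccc(CSc2nc(Nc3cccc(C(F)(F)F)c3)c3ccccc3n2)cc1` gave a measurable value of 11700 nM. Because two values sit at the limit of > 50000 nM in this assay, at which 2 of the 3 values shown sit, the step that the two limits leave unreadable from compound 1 to compound 2 cannot be read, whereas an at least 4.2-fold lower number from compound 1 to compound 3 (0.63 log units; beyond the scatter) and an at least 4.2-fold lower number from compound 2 to compound 3 (0.63 log units; beyond the scatter) show that leaving a 2-substituted phenyl brings the number down.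

Compound 4 `FC(F)(F)c1ccc(CSc2nc(Nc3ccc(Cl)cc3)c3ccccc3n2)cc1` differs from compound 1 in one place: 4-chlorophenyl in place of 2-chlorophenyl on a nitrogen on an aromatic ring. Among the compounds with values here, no measured pair covers this exact change; the only guidance is that both 2-substituted phenyls gave limits while the 3-(trifluoromethyl)phenyl did not. Compound 4 is therefore expected to land near 20000 nM, between 5000 nM and 80000 nM, an expected step of an at least 2.5-fold lower number from compound 1 to compound 4 (0.39 log units; beyond the scatter).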

Compound 4, half-maximal inhibitory concentration: 14100 nM
Beside the measured number, compound 4's estimate is 1.4-fold (0.15 log units) above it; the range from low to high includes it.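

Moving the chlorine alone, with the same atoms in the group, gives an at least 3.5-fold lower number from compound 1 to compound 4 (0.54 log units; beyond the scatter), so among these compounds where the chloro sits on the phenyl matters, and not only which group is present. The 4-chlorophenyl and the 3-(trifluoromethyl)phenyl cannot be told apart, with a 1.2-fold higher number from compound 3 to compound 4 (0.08 log units; within the scatter). The 4-chlorophenyl also separates from the 2-ethoxyphenyl, with an at least 3.5-fold lower number from compound 2 to compound 4 (0.54 log units; beyond the scatter).

Going by these compounds, the true size of the steps from compound 1 and compound 2 stays open because both values are limits: the limit of > 50000 nM in this assay, at which 2 of the 4 values shown sit. On these data alone, whether an amine or a carboxylic acid in place of the chloro would bring the number lower also stays open.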